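Carboxyphenyl Variations at the Chain End of a Shared Core

This account rests on a few compounds, and the source may have more. Where it says the series, first, only, none or still open, it means among the compounds named here.

Compound 1, `Cc1c(OCCCCOc2ccc(C(=O)O)cc2Cl)ccc(C(=O)CC2CCCC2)c1O`: > 10000 nM
Compound 2, `Cc1c(OCCCCOc2ccc(F)c(C(=O)O)c2)ccc(C(=O)CC2CCCC2)c1O`: 2490 nM
Compound 3, `Cc1c(OCCCCOc2ccccc2C(=O)O)ccc(C(=O)CC2CCCC2)c1O`: "not determined" (no result reported)

The three measured compounds share one core and differ only in the aryl acid carried at the far end of the chain. In an assay on HEK293 cells for positive allosteric modulation of metabotropic glutamate receptor 3 (Rattus norvegicus), read by thallium flux, with a stated time of 2.5 min (on this read-out higher numbers stand for an effect only at larger amounts of compound and lower numbers for an effect already at smaller amounts), compound 1 gives > 10000 nM, which is a limit of the assay and not a number. Compound 2 gives 2490 nM in this assay. Within the data shown here, the single measured step, an at least 4.0-fold lower number from compound 1 to compound 2 (0.60 log units; beyond the scatter), shows that exchanging one carboxyphenyl for another shifts the read-out beyond the scatter. Compound 3 has no number in this assay; its entry reads "not determined" (no result reported), and of the values around it one sits at the limit of > 10000 nM in this assay, at which 1 of the 3 values shown sits.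

Compound 4, `Cc1c(OCCCCOCOc2ccc(C(=O)O)cc2)ccc(C(=O)CC2CCCC2)c1O`, differs from compound 3 by (4-carboxyphenoxy)methyl in place of 2-carboxyphenyl on an oxygen on a saturated carbon. Among the measured compounds shown here, no measured step covers this change, and compound 3 offers no starting number, so no step size can be set for compound 4. The step from compound 1 to compound 2 shows only that the carboxyphenyl pattern matters, and that compound 1, with its own carboxyphenyl, rests at the limit of > 10000 nM in this assay, at which 1 of the 3 values shown sits. Compound 4 is therefore expected to give roughly 6000 nM in this assay, estimated between 1500 nM and 30000 nM, with a fair chance that only a limit is reported.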

Compound 4, half-maximal effective concentration: 1910 nM
Compound 4: the middle estimate sits 3.1-fold (0.50 log units) above what was measured; low and high end bracket the measured number.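

With (4-carboxyphenoxy)methyl on the oxygen on a saturated carbon, the read-out in this assay cannot be told apart from that with 3-carboxy-4-fluorophenyl, the step being a 1.3-fold lower number from compound 2 to compound 4 (0.12 log units; within the scatter). The same group separates clearly from 4-carboxy-2-chlorophenyl, with an at least 5.2-fold lower number from compound 1 to compound 4 (0.71 log units; beyond the scatter), so a second, differently built end group carrying a carboxylic acid now gives a lower number than compound 1, as compound 2 did. Compound 1 remains the only measured compound held at a value that is a limit of the assay and not a number: the limit of > 10000 nM in this assay, at which 1 of the 4 values shown sits.

Compound 3 still has no number, so the steps from it cannot be read and 2-carboxyphenyl at this position remains unplaced. Going by these compounds, it also stays open whether a tetrazole or a primary amide in place of the carboxylic acid, or a shorter or longer chain, would keep the read-out in the range of compound 2 and compound 4 or send it back towards the limit.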